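This account rests on a few compounds, and the source may have more. Where it says the series, first, only, none or still open, it means among the compounds named here.

Of the compounds shown here, three built on the same core have been tested in an ADME assay on HEK293 cells (Homo sapiens) for inhibition, read by CellTiter-Glo, with a stated time of 96 h, tested at 100 uM; a higher number here means more inhibition at the concentration tested (going by the name of the read-out), a lower number less inhibition. Compound 1 `CC(C)(CO)[C@H](O)C(=O)N/C=C/C(=O)OCc1ccccc1` gives -6%, compound 2 `CC(C)(C)OC(=O)/C=C/NC(=O)[C@@H](O)C(C)(C)CO` gives -8%, and compound 3 `CC(C)(C)OC(=O)/C=C\NC(=O)[C@@H](O)C(C)(C)CO` gives -11%. Compound 2 stands second highest of the three, with compound 1 nearest and compound 3 furthest, both within the scatter. The step of a number 2 percentage points lower from compound 1 to compound 2 (within the scatter) went with tert-butyl in place of benzyl on an oxygen next to a carbonyl group, and the step of a number 3 percentage points lower from compound 2 to compound 3 (within the scatter) arose because of the fact that compounds 2 and 3 differ only in the configuration as drawn. Compound 4 `CCOC(=O)/C=C/NC(=O)[C@@H](O)C(C)(C)CO` differs from compound 2 by ethyl in place of tert-butyl on an oxygen next to a carbonyl group. The ester step from compound 1 to compound 2 bears on this change and was small, so no step beyond the scatter is expected in this assay. Compound 4 is estimated to give -8%, between -20% and 5%. The step of no change at the digits printed from compound 2 to compound 4 (within the scatter) is expected to stay within the scatter.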

Compound 4, a percentage reported as inhibition, at one concentration (the size of the read-out at that concentration, not a potency): -9%
Estimate against measurement, compound 4: 1 percentage points above; low and high end bracket the measured number.
By their numbers in this assay, from the lowest: compounds 3, 4, 2 and 1 (each within the scatter of the next).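

On an oxygen next to a carbonyl group, ethyl in place of tert-butyl gave a number 1 percentage points lower from compound 2 to compound 4 (within the scatter) in this assay, so benzyl, tert-butyl and ethyl have now all been seen there without a step beyond the scatter. Methyl in place of phenyl on a saturated chain carbon bound to an oxygen next to a carbonyl group gave a number 3 percentage points lower from compound 1 to compound 4 (within the scatter) as well. Nothing at hand bears on a cause for these steps.

As far as these compounds go, whether an amine or a carboxylic acid in that place would give a step beyond the scatter remains open.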